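A few compounds are considered here, and "the series" means these few. Any claim that something is new, unique, unknown or untested is made for them only; others in the source may bear on it.

Compound 1 `CCC(C)(C)Cc1c[nH]c(CCc2ccc(-c3cnccn3)cc2)n1`, compound 2 `CCC(C)(C)Cc1c[nH]c(CCc2ccc(-c3ccc(F)cn3)cc2)n1` and compound 3 `CCC(C)(C)Cc1c[nH]c(CCc2ccc(-c3cccc(N)n3)cc2)n1` share one core and differ only in the aromatic group attached at its far end. In a functional assay on HEK293 cells for agonist activity at Bombesin receptor subtype-3 (Mus musculus), read by luminescence and calcium flux, with a stated time of 10 min (a lower number here means that less compound is needed, a higher number that more compound is needed for the effect), compound 1 gives 11 nM, compound 2 gives 16 nM and compound 3 gives 3.9 nM. Compound 3 thus stands lowest of the three: there is a 2.8-fold lower number from compound 1 to compound 3 (0.45 log units; beyond the scatter) and a 4.1-fold lower number from compound 2 to compound 3 (0.61 log units; beyond the scatter), whereas between the other two there is only a 1.5-fold higher number from compound 1 to compound 2 (0.16 log units; within the scatter).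

Compound 4 `CCC(C)(C)Cc1c[nH]c(CCc2ccc(-c3ccns3)cc2)n1` has not been measured. It differs from compound 3 in one place: 1,2-thiazol-5-yl in place of 6-aminopyridin-2-yl on an aromatic carbon. Among the measured compounds shown here, no measured step tests this entering group directly. For the measured compounds named here, the two steps that reach compound 3 both show that the one group carrying a hydrogen-bond donor gave a lower number than either group without one, by a modest margin. Compound 4 returns to a group without a donor, and it is also smaller than any group measured so far, so the expectation is that the number rises again, to roughly where compound 1 and compound 2 sit, with a 3.8-fold higher number from compound 3 to compound 4 (0.59 log units; beyond the scatter) as the expected step.

Compound 4 is therefore estimated to give about 15 nM in this assay, with a likely range from 6 nM to 40 nM.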

Compound 4, half-maximal effective concentration: 3.1 nM
The estimate for compound 4 lay 4.8-fold (0.68 log units) above the measured number; the whole stated range lies above it.
By their numbers in this assay, from the lowest: compounds 4 and 3 (each within the scatter of the next); then compounds 1 and 2 (each within the scatter of the next).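

The result removes the link suggested by the first three compounds, in which only the group with a hydrogen-bond donor, the 6-aminopyridin-2-yl of compound 3, gave the lowest number: the 1,2-thiazol-5-yl group has no donor, yet the two compounds cannot be told apart (a 1.3-fold lower number from compound 3 to compound 4 (0.10 log units; within the scatter)). A donor is therefore not needed for a low number at this position, and compound 4 goes against any rule that donor-free groups give higher numbers, since its five-membered ring also shows a clear drop compared with the six-membered, donor-free rings of the other two compounds (a 5.2-fold lower number from compound 2 to compound 4 (0.71 log units; beyond the scatter); a 3.5-fold lower number from compound 1 to compound 4 (0.55 log units; beyond the scatter)). Nothing available explains why this smaller ring does as well as the 6-aminopyridin-2-yl group.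

With only one five-membered ring shown, it remains open whether the low number belongs to five-membered rings in general or to this particular arrangement of sulfur and nitrogen, which a thiophene or a 1,3-thiazole would help to separate. As far as these compounds go, it is also open whether an amine added to the 1,2-thiazol-5-yl ring would lower the number further or leave it unchanged.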